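The source may report more compounds than this note shows. Statements on the series, on what has been measured and on what is new or still open speak of the compounds shown alone.

Compound 1 `COc1cccc(C=C2C(=O)N(c3ccc(Cl)cc3)N(c3ccc(Cl)cc3)C2=O)c1O` gives 39000 nM in a functional assay on ECa-109 cells (Homo sapiens) for cytotoxicity, read by MTT assay, with a stated time of 72 h; on this read-out higher numbers stand for weaker inhibition and lower numbers for stronger inhibition.
Compound 2 `COc1cccc(C=C2C(=O)N(c3ccc(Cl)cc3)N(c3ccc(Cl)cc3)C2=O)c1OC` gives 6800 nM in this assay.

Among these two measured compounds, compound 2 holds the lowest number in this assay, that is, the stronger inhibition; its only neighbour is compound 1, and the one measured step between them, a 5.7-fold lower number from compound 1 to compound 2 (0.76 log units; beyond the scatter), comes from methyl in place of hydrogen on an oxygen on an aromatic ring.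

Compound 3 `O=C1C(=C/C=C/c2ccccc2)C(=O)N(c2ccc(Cl)cc2)N1c1ccc(Cl)cc1` is not yet measured. It differs from compound 2 as follows: 2-phenylethenyl in place of 2,3-dimethoxyphenyl on a double-bonded chain carbon bound to a double-bonded ring carbon. For the measured compounds named here, the one measured step does not bear on this change, since it touched only a single methyl on an oxygen, while here the whole 2,3-dimethoxyphenyl leaves and a 2-phenylethenyl enters on the double-bonded chain carbon bound to a double-bonded ring carbon. There is therefore no measured guide to how large the change will be or in which direction, and a wide range is appropriate. In this assay compound 3 is estimated to give about 10000 nM, with a range from 2000 nM to 50000 nM. This estimate would mean a 1.5-fold higher number from compound 2 to compound 3 (0.17 log units; within the scatter), a step expected to stay near the scatter.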

Compound 3, half-maximal inhibitory concentration: 9900 nM
The estimate for compound 3 lay 1.0-fold (0.00 log units) above the measured number; the measured number falls inside the stated range.
By their numbers in this assay, from the lowest: compounds 2 and 3 (each within the scatter of the next); then compound 1.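

On the double-bonded chain carbon bound to a double-bonded ring carbon, the whole 2,3-dimethoxyphenyl gives way to 2-phenylethenyl with no readable difference in this assay: the change is a 1.5-fold higher number from compound 2 to compound 3 (0.16 log units; within the scatter), even though the entering group holds carbon only and has a double bond outside aromatic rings. Set against the 2-hydroxy-3-methoxyphenyl group, the same entering group gives a 3.9-fold lower number from compound 1 to compound 3 (0.60 log units; beyond the scatter), so among these three compounds neither oxygen on the aromatic ring is needed to reach the level of compound 2, and the free hydroxyl of compound 1 goes with the weakest inhibition. Nothing available explains why these numbers fall as they do.

The compounds shown leave open whether the double bond in the 2-phenylethenyl chain matters, which a saturated 2-phenylethyl chain or a longer chain with further double bonds in the same place could test. They also leave open how an amine or a carboxylic acid on the aromatic ring of that chain would shift the number in this assay.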